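The compounds below may be only part of what the source reports. "The series", "measured", "known", "first", "only" and "open" are said of these compounds alone.

Measured in a physicochemical assay for solubility, read by HPLC, at pH 6.8; on this read-out lower numbers stand for lower solubility and higher numbers for higher solubility:
compound 1 `CC(C)(C)c1cc(NC(=O)[C@@H]2CCCCN2C(=O)N2CCCCC2)no1`, 49 ug/mL
compound 2 `CCC(=O)N1CCN(C(=O)N2CCCC[C@H]2C(=O)Nc2cc(C(C)(C)C)on2)CC1`, 68 ug/mL

Within the data shown here, compound 2 holds the higher of the two numbers, yet the only measured step, a 1.4-fold higher number from compound 1 to compound 2 (0.14 log units; within the scatter), lies within the scatter, so the two compounds are not separated. Compound 3 `CC(C)(C)c1cc(NC(=O)[C@@H]2CCCCN2C(=O)N2CCSCC2)no1` differs from compound 2 by thiomorpholin-4-yl in place of 4-propanoylpiperazin-1-yl on a carbonyl carbon. The step bearing on this change is a 1.4-fold higher number from compound 1 to compound 2 (0.14 log units; within the scatter), which was small; compound 3, like compound 1, carries no propanoyl group, so no step beyond the scatter is expected. For compound 3 the expected step is a 1.5-fold lower number from compound 2 to compound 3 (0.18 log units; within the scatter), an estimate of 45 ug/mL with a range from 15 ug/mL to 110 ug/mL.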

Compound 3, solubility: 46 ug/mL
Beside the measured number, compound 3's estimate is 1.0-fold (0.01 log units) below it, and the stated range covers the measured number.
By their numbers in this assay, from the lowest: compounds 3, 1 and 2 (each within the scatter of the next).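

At this carbonyl carbon, thiomorpholin-4-yl now stands alongside piperidin-1-yl and 4-propanoylpiperazin-1-yl, and in this assay both new steps stay within the scatter: a 1.5-fold lower number from compound 2 to compound 3 (0.17 log units; within the scatter), and a 1.1-fold lower number from compound 1 to compound 3 (0.03 log units; within the scatter). All three groups at this place therefore remain unseparated on this read-out, so the sulfur-containing ring gives no distinct result here. No supporting data accompany this result to account for it.

Open, as far as these compounds go, is whether a carboxylic acid or a primary amine on the group at this carbonyl carbon would give a step beyond the scatter. From the compounds shown here alone, an open-chain dialkylamino group in place of these rings also remains open.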